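The compounds below may be only part of what the source reports. "The series", "measured", "known", "first", "only" and "open" are said of these compounds alone.

In a functional assay on HEK293 cells for agonist activity at G-protein coupled receptor 39 (Mus musculus), read by inositol phosphate accumulation (a lower number here means that less compound is needed, a higher number that more compound is needed for the effect), compound 2 `c1ccc(-c2cc(NCC3CC3)ncn2)nc1` gives 10000 nM, the highest of the three numbers recorded. Compound 1 `CNc1nc(NCC(C)(C)C)cc(-c2ccccn2)n1` gives 365 nM, and compound 3 `CNc1nc(NCc2ccc(Cl)cc2)cc(-c2ccccn2)n1` gives 3 nM. For the measured compounds named here, the one step recorded among the measured compounds, a 120-fold lower number from compound 1 to compound 3 (2.09 log units; beyond the scatter), concerns a different site, the saturated chain carbon bound to a nitrogen on the ring, and so does not bear directly on the change in question. Compound 4 `CC(C)(C)CNc1nc(NCC2CC2)cc(-c2ccccn2)n1` differs from compound 2 by neopentylamino in place of hydrogen on an aromatic carbon. Going by the values given here, no measured pair isolates this change; what the numbers show is that compound 1 and compound 3, which both carry an amino substituent on that aromatic carbon, give far lower numbers than compound 2, which carries hydrogen there. On that basis a substantial decrease is expected for compound 4, estimated as a 33-fold lower number from compound 2 to compound 4 (1.52 log units; beyond the scatter). Compound 4 is therefore expected to give about 300 nM in this assay, within a range from 50 nM to 2000 nM.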

Compound 4, half-maximal effective concentration: 1500 nM
For compound 4 the middle estimate is 5.0-fold (0.70 log units) below the measured one; measured number inside the range.
By their numbers in this assay, from the lowest: compound 3; then compound 1; then compound 4; then compound 2.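

In this assay, for the compounds shown here, the step of a 6.7-fold lower number from compound 2 to compound 4 (0.82 log units; beyond the scatter) is the first direct reading of neopentylamino in place of hydrogen on this aromatic carbon, between two ring nitrogen atoms. The step is modest but beyond the scatter, so the substituent is tolerated here and lowers the number with the (cyclopropylmethyl)amino group unchanged, something compound 1 and compound 3 could not show, as each differs from compound 2 in more than one place. Nothing at hand explains the size of this step.

The compounds shown leave open how a plain amino group or a methoxy group on this aromatic carbon would compare with hydrogen and neopentylamino. They also leave open whether the step would keep its size with a hexylamino chain in place of the (cyclopropylmethyl)amino group.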